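The source may hold more compounds than are shown below. What is called first, only, known or untested is meant among the compounds shown, and "the series" means these compounds.

Of the compounds shown here, three sharing a common core have been measured in an ADME assay on HEL cells (Homo sapiens) for cytotoxicity; a lower number here means that less compound is tolerated, a higher number that more compound is tolerated. Compound 1 `C/C(=N\NC(=O)COc1cccc2ccccc12)c1cccc([N+](=O)[O-])c1` gives 10.5 ug/mL in this assay. Compound 2 `O=C(COc1cccc2ccccc12)N/N=C/C=C/c1ccccc1` gives 100 ug/mL, and compound 3 `COc1cc(/C=N/NC(=O)COc2cccc3ccccc23)cc(OC)c1OC` gives 47.9 ug/mL. Compound 1 therefore has the lowest number of the three: the nearest to it, compound 3, lies higher by more than the usual scatter, and compound 2 lies higher still, also beyond the scatter. Less of compound 1 is tolerated by the cells than of either companion.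

Compound 4 `C/C(=N\NC(=O)COc1cccc2ccccc12)c1ccc([N+](=O)[O-])cc1` has not been measured yet. It differs from compound 1 in one place: 4-nitrophenyl in place of 3-nitrophenyl on a carbon with a double bond to nitrogen. The two have the same atoms joined differently, so they are isomers of one another. Among the measured compounds shown here, none of the measured compounds shows how a change of this kind moves the read-out, so the expectation rests on the small size of the change alone. The step expected is a 1.1-fold higher number from compound 1 to compound 4 (0.06 log units; within the scatter), no larger than the scatter and with no clear direction. Compound 4 is expected to give about 12 ug/mL, with a range from 5 ug/mL to 30 ug/mL.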

Compound 4, half-maximal cytotoxic concentration: > 100 ug/mL
Compound 4 gave a limit, no number (the forecaster's own chance of this, stated with the estimate: 5%); middle value at least 8.3-fold (0.92 log units) from the limit.
By their numbers in this assay, from the lowest: compound 1; then compound 3; then compound 2.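

At this place on the shared core, a carbon with a double bond to nitrogen, replacing 3-nitrophenyl with 4-nitrophenyl proves to be no small change in this assay: the atoms stay the same, yet the step is an at least 9.5-fold higher number from compound 1 to compound 4 (0.97 log units; beyond the scatter). Among the compounds shown here, this pair therefore shows what the earlier compounds, none differing from another in one place, could not: how the same atoms are joined can alone separate a poorly tolerated compound from a much better tolerated one. The true size of the step remains unknown, since compound 4 stands at a limit of the assay and not at a number: the limit of > 100 ug/mL in this assay, at which 1 of the 4 values shown sits.

As far as these compounds go, the reason for this large step remains open, as does whether it is particular to the nitro group. A 4-aminophenyl or 4-carboxyphenyl group at the same place could test whether other groups behave like 4-nitrophenyl.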